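Notes on a hydroxy to hydrogen step in the series

The compounds below may be only part of what the source reports. "The series", "measured", "known", "first", "only" and "open" are said of these compounds alone.

Values in a functional assay on CAKI-1 cells (Homo sapiens) for inhibition (on this read-out higher numbers stand for weaker inhibition of growth and lower numbers for stronger inhibition of growth), for the measured compounds
compound 1 `COc1cc(/C=C/c2ccc(S(N)(=O)=O)cc2)cc(OC)c1` gives 19000 nM
compound 2 `NS(=O)(=O)c1ccc(/C=C/c2ccc(O)c(O)c2)cc1` gives 29100 nM
compound 3 `COc1cccc(/C=C/c2ccc(S(N)(=O)=O)cc2)c1` gives 14700 nM

In this assay compound 2 lies within the scatter of both compound 1 and compound 3, so the three values show no order among them. The next step leads from compound 2 to compound 4 `NS(=O)(=O)c1ccc(/C=C/c2ccc(O)cc2)cc1` and is described by hydrogen in place of hydroxy on an aromatic carbon as hydrogen in place of hydroxy on an aromatic carbon. The group that leaves sits ortho to a hydroxy group, which stays, and meta to a large group.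

Among the compounds with values here, no measured step removes a hydroxy group, so direct evidence is lacking. The closest guide is a 1.3-fold lower number from compound 1 to compound 3 (0.11 log units; within the scatter) for hydrogen in place of methoxy on an aromatic carbon, a step within the scatter. That single step involves a different group and gives only weak support, but it offers no reason to expect a large change. The expected result is a 1.5-fold lower number from compound 2 to compound 4 (0.16 log units; within the scatter) and this estimated step stays within the scatter, with no firm direction. In this assay the estimate for compound 4 is 20000 nM with an expected range from 10000 nM to 40000 nM as its limits.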

Compound 4, concentration for 50% growth inhibition: 5590 nM
Compound 4: middle estimate off by 3.6-fold (0.55 log units), on the high side, and the stated range ends above it.
By their numbers in this assay, from the lowest: compound 4; then compounds 3, 1 and 2 (each within the scatter of the next).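

In this assay, within the data shown here, the change of hydroxy to hydrogen gives a 5.2-fold lower number from compound 2 to compound 4 (0.72 log units; beyond the scatter), the first step that lies beyond the scatter; the only earlier step, a 1.3-fold lower number from compound 1 to compound 3 (0.11 log units; within the scatter), involved methoxy and stayed within it. The position ortho to a hydroxy group and meta to a large group is therefore one where a single heavy atom makes a readable difference, and the direction is towards stronger inhibition of growth, so a hydroxy group here is not required for this read-out and the remaining hydroxy group alone goes with the better number. This rests on one pair, and nothing measured on the compounds explains the size or direction of the step.

The compounds shown do not tell whether any substituent at this place lowers the number or only its absence does, since no group other than hydroxy and hydrogen has been compared here; an amine or a fluorine at the same carbon would separate these readings. Among these compounds, also open is what the remaining hydroxy group contributes, as no pair shows its replacement by hydrogen or by a carboxylic acid.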